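Swapping an aromatic ring on the shared core

The compounds below may be only part of what the source reports. "The series", "measured", "known", "first", "only" and "open" are said of these compounds alone.

Values so far in a functional assay on Shh Light II cells (Mus musculus) for inhibition, read by a luciferase reporter (on this read-out lower numbers stand for stronger inhibition and higher numbers for weaker inhibition), are:
- compound 1 `O=C(Nc1ccccc1C(F)(F)F)N1CCC(c2nc(-c3ccc4ccccc4n3)no2)CC1` gives 700 nM
- compound 2 `COc1ccccc1NC(=O)N1CCC(c2nc(-c3ccc4ccccc4n3)no2)CC1` gives 410 nM

Going by the values given here, only one step has been measured, a 1.7-fold lower number from compound 1 to compound 2 (0.23 log units; within the scatter) with methoxy in place of trifluoromethyl on an aromatic carbon. Among the compounds with values here, compound 2 therefore stands level with the only other compound measured, and neither can be ranked above the other.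

The next compound, compound 3 `O=C(NC1CCOCC1)N1CCC(c2nc(-c3ccc4ccccc4n3)no2)CC1`, keeps the shared core but changes a larger piece: oxan-4-yl in place of 2-methoxyphenyl on an amide-type nitrogen. In short, it has oxan-4-yl in place of 2-methoxyphenyl on an amide-type nitrogen.

The measured step bears on this only loosely, since both measured compounds keep an aromatic ring there. Within the data shown here, no measured pair shows what happens when that ring is lost. A step beyond the scatter is therefore possible, and a higher number in this assay seems somewhat more likely than a lower one. The estimated step is a 2.9-fold higher number from compound 2 to compound 3 (0.47 log units; beyond the scatter) with considerable uncertainty. Compound 3 is expected near 1200 nM with 300 nM to 5000 nM as the estimated range.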

Compound 3, half-maximal inhibitory concentration: 480 nM
Compound 3: the middle estimate sits 2.5-fold (0.40 log units) above what was measured, within the range that was stated.
By their numbers in this assay, from the lowest: compounds 2, 3 and 1 (each within the scatter of the next).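

In this assay the position on the amide-type nitrogen still gives closely matched numbers once the aromatic ring is gone: the change from 2-methoxyphenyl to oxan-4-yl gives a 1.2-fold higher number from compound 2 to compound 3 (0.07 log units; within the scatter) and the change from 2-(trifluoromethyl)phenyl to oxan-4-yl gives a 1.5-fold lower number from compound 1 to compound 3 (0.16 log units; within the scatter) on the same core. Compounds 1 and 2 both carry a six-membered aromatic ring of carbon only at this place, so they could not show whether such a ring is needed, whereas compound 3 shows that, at least on this core, a non-aromatic ring with one oxygen can stand there with no step beyond the scatter. No outside measurement is at hand to explain why these rings read alike, so this remains an observation only.

Still open, as far as these compounds go, is what a group with no ring at all, such as a plain ethyl chain, would give at this nitrogen. Also open, from the compounds shown here alone, is what a ring carrying an amine or a carboxylic acid would give there.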